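Swapping methoxy for dimethylamino on compound 1

A few compounds are considered here, and "the series" means these few. Any claim that something is new, unique, unknown or untested is made for them only; others in the source may bear on it.

Compound 1 `COc1ccc(C2CC(c3ccccc3)=NN2C2=NC(=O)/C(=C3\C(=O)Nc4ccccc43)S2)cc1` is the weakest growth inhibitor of the three measured here: in a functional assay on cells (Cancer cell lines, Homo sapiens) for cytotoxicity, read by sulforhodamine B assay, with a stated time of 48 h (a lower number here means a stronger inhibitor of growth, a higher number a weaker inhibitor of growth), compound 1 gives 1620 nM. Two changes elsewhere in the molecule lowered that number. Compound 2 `COc1ccc(C2CC(c3ccccc3)=NN2C2=NC(=O)/C(=C3\C(=O)Nc4ccc(Br)cc43)S2)cc1` gives 180 nM, a step of a 9.0-fold lower number from compound 1 to compound 2 (0.95 log units; beyond the scatter). Compound 3 `COc1ccc(C2CC(c3ccc4ccccc4c3)=NN2C2=NC(=O)/C(=C3\C(=O)Nc4ccccc43)S2)cc1` gives 670 nM, a step of a 2.4-fold lower number from compound 1 to compound 3 (0.38 log units; beyond the scatter). Compound 4 `CN(C)c1ccc(C2CC(c3ccccc3)=NN2C2=NC(=O)/C(=C3\C(=O)Nc4ccccc43)S2)cc1` carries a different change, (dimethylamino in place of methoxy on an aromatic carbon). Among the compounds with values here, neither measured step touches this part of the molecule, so no measured step bears directly on it. The change is expected to give only a small shift, a 1.4-fold lower number from compound 1 to compound 4 (0.13 log units; within the scatter), within or just beyond the scatter. Compound 4 is therefore estimated at 1200 nM, with a likely range from 400 nM to 4000 nM.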

Compound 4, concentration for 50% growth inhibition: 1110 nM
Beside the measured number, compound 4's estimate is 1.1-fold (0.03 log units) above it; low and high end bracket the measured number.
By their numbers in this assay, from the lowest: compound 2; then compounds 3, 4 and 1 (each within the scatter of the next, the first and the last beyond it).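

Within the data shown here, this is the first measured change at the 4-methoxyphenyl group, and it gives a 1.5-fold lower number from compound 1 to compound 4 (0.16 log units; within the scatter) in this assay. Dimethylamino can therefore stand in place of methoxy at this site with no shift beyond the scatter, whereas the bromo and naphthalen-2-yl steps elsewhere on the molecule both went beyond it. Nothing available explains this result. On these data alone, whether a carboxylic acid, a primary amine or a longer chain such as butoxy at this site would move the number remains open. So does whether dimethylamino would behave the same way alongside the bromo of compound 2.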